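The source may hold more compounds than are shown below. What is called first, only, known or untested is meant among the compounds shown, and "the series" means these compounds.

Working notes on the series. Of the compounds shown here, three of the shared core have been measured in a functional assay on T47D cells (Homo sapiens) for inhibition, read by sulforhodamine B assay, with a stated time of 48 h, tested at 10 uM; on this read-out lower numbers stand for less inhibition and higher numbers for more inhibition at the one concentration tested (going by the name of the read-out). Compound 1 `Brc1cn2ccnc2c(-c2ccc3ncn(C4CCCCC4)c3c2)n1` gives 49.7%. Compound 2 `Fc1ccc(-c2cn3ccnc3c(-c3ccc4ncn(C5CCCCC5)c4c3)n2)cc1` gives 33.3% in this assay, a change of a number 16.4 percentage points lower from compound 1 to compound 2 (beyond the scatter). Compound 3 `c1cn2cc(-c3ccsc3)nc(-c3ccc4ncn(C5CCCCC5)c4c3)c2n1` gives 63.7% in this assay; the step is a number 14 percentage points higher from compound 1 to compound 3 (beyond the scatter) and, against compound 2, a number 30.4 percentage points higher from compound 2 to compound 3 (beyond the scatter). Compound 3 thus stands highest of the three numbers, with compound 1 nearest and compound 2 furthest, both beyond the scatter.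

Compound 4 `c1csc(-c2cn3ccnc3c(-c3ccc4ncn(C5CCCCC5)c4c3)n2)c1` is not yet measured. It differs from compound 3 by thiophen-2-yl in place of thiophen-3-yl on an aromatic carbon. Among the measured compounds shown here, no measured step swaps one thiophenyl for another; the steps into compound 3 only show that the group on this aromatic carbon moves the read-out by modest to large amounts. The two thiophenyl groups are counted alike, so no step beyond the scatter is expected in this assay, though the measured steps leave room for some movement either way. Compound 4 is expected to give 58%, within 40% to 75%, an estimated step of a number 5.7 percentage points lower from compound 3 to compound 4 (within the scatter).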

Compound 4, a percentage reported as inhibition, at one concentration (the size of the read-out at that concentration, not a potency): 70.3%
The estimate for compound 4 lay 12.3 percentage points below the measured number; measured number inside the range.
By their numbers in this assay, from the lowest: compound 2; then compound 1; then compounds 3 and 4 (each within the scatter of the next).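

In this assay, thiophen-2-yl in place of thiophen-3-yl on this aromatic carbon gives a number 6.6 percentage points higher from compound 3 to compound 4 (within the scatter), so the position does not separate the two thiophenyl groups. Thiophen-2-yl also stands clear of the other two groups at this carbon, with a number 20.6 percentage points higher from compound 1 to compound 4 (beyond the scatter) against bromo and a number 37 percentage points higher from compound 2 to compound 4 (beyond the scatter) against 4-fluorophenyl, so both thiophenyl groups now lie beyond the scatter of bromo and 4-fluorophenyl. No independent data bear on why these groups differ at this position.

From the compounds shown here alone, whether the same level holds for another five-membered aromatic ring such as furan-2-yl, or for an amine or a carboxylic acid on this carbon, stays open. Going by these compounds, the numbers in this assay come from one concentration, so the potency of compound 3 and compound 4 also stays open.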